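One Group Exchanged on an Aromatic Nitrogen

The compounds below may be only part of what the source reports. "The series", "measured", "known", "first", "only" and "open" are said of these compounds alone.

Among the measured compounds shown here, in a functional assay on BALB/3T3 cells (Mus musculus) for antiproliferative activity, read by MTT assay, with a stated time of 72 h (on this read-out higher numbers stand for weaker inhibition of growth and lower numbers for stronger inhibition of growth), compound 2 `Cc1ccc(-n2nnc(C(=O)Nc3ccc(SC#N)cc3)c2C)cc1C` gives 9800 nM, the only actual number so far. Compound 1 `Cc1c(C(=O)Nc2ccc(SC#N)cc2)nnn1-c1ccc(C(C)C)cc1` is reported only as a limit, > 100000 nM. Just one measured step bears on what comes next: an at least 10-fold lower number from compound 1 to compound 2 (1.00 log units; beyond the scatter), with 3,4-dimethylphenyl in place of 4-isopropylphenyl on an aromatic nitrogen. On these data alone, since one end of that step is a limit, its true size is unknown, but it shows that a change at this place can move the number considerably. Compound 3 `Cc1ccc(Cl)cc1-n1nnc(C(=O)Nc2ccc(SC#N)cc2)c1C` changes the same place, with 5-chloro-2-methylphenyl in place of 3,4-dimethylphenyl (5-chloro-2-methylphenyl in place of 3,4-dimethylphenyl on an aromatic nitrogen). For the measured compounds named here, no measured step involves a chlorine, so the direction stays open and the range must be wide. The expected change is a 1.2-fold higher number from compound 2 to compound 3 (0.09 log units; within the scatter). Compound 3 is estimated at 12000 nM, with an expected range from 3000 nM to 50000 nM.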

Compound 3, concentration for 50% growth inhibition: 9900 nM
Beside the measured number, compound 3's estimate is 1.2-fold (0.08 log units) above it, and the stated range covers the measured number.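

Swapping 3,4-dimethylphenyl for 5-chloro-2-methylphenyl on the aromatic nitrogen gives a 1.0-fold higher number from compound 2 to compound 3 (0.00 log units; within the scatter) in this assay, so these two groups cannot be told apart here. The earlier step showed that a change at this position can move the number, and this one shows that a change of group here need not do so. Set against 4-isopropylphenyl, the new group gives an at least 10-fold lower number from compound 1 to compound 3 (1.00 log units; beyond the scatter), so the drop seen earlier is not peculiar to the 3,4-dimethylphenyl group.

On these data alone, compound 1 is a limit and not a number, so the true size of both of its steps stays open: the limit of > 100000 nM in this assay, at which 1 of the 3 values shown sits. Also open is how a phenyl ring carrying an amine or a carboxylic acid, or a longer alkyl chain in place of the ring, would behave on this nitrogen.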